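The source may report more compounds than this note shows. Statements on the series, on what has been measured and on what is new or still open speak of the compounds shown alone.

Going by the values given here, compound 2 `CCN(CCCOc1ccc(C(=O)/C=C/c2ccc(N(C)C)cc2)c(O)c1)Cc1ccccc1N(C)C` stands lowest of the two numbers so far in an assay on isolated protein for inhibition of Amine oxidase [flavin-containing] B (Homo sapiens); a lower number here means a stronger inhibitor, a higher number a weaker inhibitor: compound 2 gives 3200 nM, while compound 1 `CCN(CCCOc1ccc(C(=O)/C=C/c2ccc(N(C)C)cc2)c(O)c1)Cc1ccccc1` gives 13100 nM. Among the compounds with values here, the single measured step, a 4.1-fold lower number from compound 1 to compound 2 (0.61 log units; beyond the scatter), concerns adding the dimethylamino group rather than moving it. Compound 3 `CCN(CCCOc1ccc(C(=O)/C=C/c2ccc(N(C)C)cc2)c(O)c1)Cc1ccc(N(C)C)cc1` differs from compound 2 by 4-(dimethylamino)phenyl in place of 2-(dimethylamino)phenyl on a saturated chain carbon bound to an amine nitrogen. Within the data shown here, no measured step speaks to this change, so nothing beyond the scatter is expected in this assay in either direction; the expected step is no change at the digits printed from compound 2 to compound 3 (within the scatter). For compound 3 the estimate is 3200 nM, with a range of 1000 nM to 10000 nM.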

Compound 3, half-maximal inhibitory concentration: 13700 nM
Compound 3: the middle estimate sits 4.3-fold (0.63 log units) below what was measured; measured number above the stated range.
By their numbers in this assay, from the lowest: compound 2; then compounds 1 and 3 (each within the scatter of the next).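

In this assay the placement of the dimethylamino group counts: going from 2-(dimethylamino)benzyl to 4-(dimethylamino)benzyl gives a 4.3-fold higher number from compound 2 to compound 3 (0.63 log units; beyond the scatter). The 4-(dimethylamino)benzyl group does not separate from the plain benzyl group, with a 1.0-fold higher number from compound 1 to compound 3 (0.02 log units; within the scatter), so among these three only the 2-(dimethylamino)benzyl group of compound 2 stands apart. Nothing measured bears on why the two placements differ. Going by these compounds, whether methoxy or pyrrolidinyl in place of the dimethylamino group on the 2-(dimethylamino)benzyl group would hold the number of compound 2 stays open.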